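Methyl in place of methoxy on the sulfonyl aryl ring

This account rests on a few compounds, and the source may have more. Where it says the series, first, only, none or still open, it means among the compounds named here.

Measured so far:
- Compound 1, `CCCCCS(=O)(=O)NNC(=O)[C@@H](NC(=O)c1cccc(Cn2ccnc2)c1)[C@@H](C)CC`, in an assay on HEK293 cells for displacement of a labelled ligand from Type-2 angiotensin II receptor (Homo sapiens), tested at 10 uM (on this read-out higher numbers stand for a stronger effect at the one concentration tested and lower numbers for a weaker effect), compound 1 has "not determined" (no result reported).
- Compound 2, `CC[C@H](C)[C@H](NC(=O)c1cccc(Cn2ccnc2)c1)C(N)=O`, in this assay compound 2 is "not active" (no number reported).
- Compound 3, `CC[C@H](C)[C@H](NC(=O)c1cccc(Cn2ccnc2)c1)C(=O)NNS(=O)(=O)c1ccc(OC)cc1`, in this assay compound 3 gives 20%.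

Compound 3 is the only one of the three with a number to its name; compound 1 has no result reported and compound 2 is reported without a number. So compound 3 stands alone as the single reference point, and its reading is modest.

Compound 4, `CC[C@H](C)[C@H](NC(=O)c1cccc(Cn2ccnc2)c1)C(=O)NNS(=O)(=O)c1ccc(C)cc1`, keeps the shared core of compound 3 and changes only the substituent on the aryl sulfonyl: methyl in place of methoxy on an aromatic carbon, on an aromatic carbon of a six-membered aromatic ring of carbon only, para to a large group. Among the measured compounds shown here, no pair of measured compounds shows what such a swap does here, so there is nothing to lean on beyond compound 3 itself. Since a methyl and a methoxy are small groups in the same spot, the step of a number 2 percentage points lower from compound 3 to compound 4 (within the scatter) is expected to stay within the usual scatter, in no clear direction. Compound 4 is therefore estimated at 18%, with a plausible range from 5% to 35%.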

Compound 4, a percentage reported as inhibition, at one concentration (the size of the read-out at that concentration, not a potency): 20%
Compound 4: the middle estimate sits 2 percentage points below what was measured; the measured number falls inside the stated range.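

In this assay, among the compounds shown here, replacing the 4-methoxyphenyl with the 4-methylphenyl on the sulfonyl gives no change at the digits printed from compound 3 to compound 4 (within the scatter) and provides the first direct comparison at this position. Exchanging methoxy for methyl removes an oxygen and a hydrogen-bond acceptor, yet the read-out stays within the usual scatter, so this pair shows no need for that oxygen at the one concentration tested. No measurement here explains why the two compounds read alike.

Going by these compounds, it remains open whether this position accepts groups beyond these two, such as an amine, a carboxylic acid or a longer chain on the ring. Also open, on these data alone, are what hydrogen in this place would give and whether a reading at a single concentration hides a difference in potency between compound 3 and compound 4.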